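The source may hold more compounds than are shown below. What is called first, only, known or untested is meant among the compounds shown, and "the series" means these compounds.

Measured compounds:
compound 1 `CCCc1nc(C)c2c(C)nn(CCC)c(=O)n12`: > 48000 nM
compound 2 `Cc1nc(C)n2c(=O)n(C)ncc12`: > 48000 nM

In a functional assay for inhibition, with Homo sapiens as the target (a higher number here means a weaker inhibitor, a lower number a stronger inhibitor), compound 1 gives > 48000 nM, which is a limit of the assay rather than a number. Compound 2 in this assay likewise gives only a limit, > 48000 nM. Both shown values thus sit at the limit of > 48000 nM in this assay, at which 2 of the 2 values shown sit, and compound 1 stands at that limit with no number to place it against anything else. Going by the values given here, no step between measured compounds is available, so the size of a change in this assay cannot be read from these two compounds.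

Compound 3 `CCCc1nc(C)c2c(C)nn(CC(=O)OCC)c(=O)n12` differs from compound 1 by ethoxycarbonyl in place of ethyl on a saturated chain carbon bound to an aromatic nitrogen. With both measured compounds at the limit, the step that the limit leaves unreadable from compound 1 to compound 3 is expected to be none beyond the scatter. Compound 3 is therefore estimated at 60000 nM in this assay, with a range from 20000 nM to 200000 nM, and the assay would most likely again report only a limit for compound 3.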

Compound 3, half-maximal inhibitory concentration: > 48000 nM
Compound 3: no number, only a limit; the forecaster's own chance of this, stated with the estimate: 85%; the middle value lies beyond the limit too.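

No step can be read between compound 1 and compound 3, since each gives only a limit of the assay and no number: the limit of > 48000 nM in this assay, at which 3 of the 3 values shown sit. The compounds shown leave open how strongly any of them inhibits in this assay, and whether ethoxycarbonyl in place of ethyl changes that at all.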